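The source may report more compounds than this note shows. Statements on the series, on what has been measured and on what is new or still open speak of the compounds shown alone.

Compounds measured so far in a functional assay for inhibition, with Rattus norvegicus as the target, at pH 7.35 (on this read-out lower numbers stand for stronger inhibition and higher numbers for weaker inhibition), are these two.
- compound 1 `CCCCNC(=O)C(=O)C(CC)NC(=O)C(CC(C)C)NC(=O)OCc1ccccc1` gives 35000 nM
- compound 2 `CCCCCCCCNC(=O)C(=O)C(CC)NC(=O)C(CC(C)C)NC(=O)OCc1ccccc1` gives 200000 nM

Among the compounds with values here, compound 2 holds the higher of the two numbers, making it the weaker inhibitor of the pair, and compound 1 is its only neighbour. Compound 3 `CCC(NC(=O)C(CC(C)C)NC(=O)OCc1ccccc1)C(=O)C(=O)NCCCc1ccccc1` keeps the shared core but carries 3-phenylpropyl in place of the octyl of compound 2, a change that counts as phenyl in place of pentyl on a saturated chain carbon, three bonds along the chain from an amide-type nitrogen in full.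

Within the data shown here, one measured step bears on this: a 5.7-fold higher number from compound 1 to compound 2 (0.76 log units; beyond the scatter), a modest step beyond the scatter, made on the same chain. Among the measured compounds shown here, that step changes chain length only, and no compound with an aromatic ring on this chain has been measured, so it gives a rough scale and little guidance on direction. With compound 2 at 200000 nM as the top of the range so far, a modest move to a lower number in this assay is expected, with weak confidence. The estimate amounts to a 2.9-fold lower number from compound 2 to compound 3 (0.46 log units; beyond the scatter) as the expected step. For compound 3 the estimated value is 70000 nM, with an expected range from 20000 nM to 200000 nM in this assay.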

Compound 3, half-maximal inhibitory concentration: 100000 nM
Beside the measured number, compound 3's estimate is 1.4-fold (0.15 log units) below it; low and high end bracket the measured number.
By their numbers in this assay, from the lowest: compound 1; then compounds 3 and 2 (each within the scatter of the next).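

In this assay, phenyl in place of pentyl, on a saturated chain carbon, three bonds along the chain from an amide-type nitrogen, gives a 2.0-fold lower number from compound 2 to compound 3 (0.30 log units; within the scatter), so on this read-out 3-phenylpropyl and octyl cannot be told apart, and an aromatic ring at this place shows no separate effect of its own. Set against the butyl of compound 1, the same chain gives a 2.9-fold higher number from compound 1 to compound 3 (0.46 log units; beyond the scatter), which leaves compound 1 the strongest of the three, with octyl and 3-phenylpropyl both beyond the scatter from butyl whether or not the chain carries a ring. No supporting data are available to account for these numbers.

The compounds shown leave open whether benzyl or phenethyl would read differently from 3-phenylpropyl, and whether a shorter chain such as propyl or ethyl would give a lower number than butyl. They also leave open how a carboxylic acid or an amine in place of the phenyl would read in this assay on this series.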